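The compounds below may be only part of what the source reports. "The series", "measured", "known", "first", "only" and "open" are said of these compounds alone.

Measured compounds in a functional assay on A549 cells (Homo sapiens) for inhibition, read by sulforhodamine B assay, with a stated time of 48 h; on this read-out higher numbers stand for weaker inhibition of growth and lower numbers for stronger inhibition of growth:
compound 1 `COc1cc(-c2nn(-c3cccc(NC(=O)Nc4cc(C(F)(F)F)cc(C(F)(F)F)c4)c3)cc2-c2ccncc2)ccc1Cl` gives 527 nM
compound 2 `COc1cc(-c2nn(-c3cccc(NC(=O)Nc4ccc(Cl)c(Cl)c4)c3)cc2-c2ccncc2)ccc1Cl` gives 745 nM
compound 3 `O=C(Nc1cccc(-n2cc(-c3ccncc3)c(-c3ccc(Cl)c(O)c3)n2)c1)Nc1ccc(Cl)c(Cl)c1` gives 1010 nM

Compound 1 carries the lowest number of the three, but its gaps to compound 2 and to compound 3 both sit within the scatter, so no order among them can be stated. Among the measured compounds shown here, the one step between neighbours that differ in a single place, a 1.4-fold higher number from compound 2 to compound 3 (0.13 log units; within the scatter), concerns a change on the other end of the shared core and also stays within the scatter.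

Compound 4 `COc1cc(-c2nn(-c3cccc(NC(=O)Nc4cccc(C(F)(F)F)c4)c3)cc2-c2ccncc2)ccc1Cl` is the next member, not yet measured in this assay. It differs from compound 1 by hydrogen in place of trifluoromethyl on an aromatic carbon. No measured pair reproduces this change, so nothing bears on it directly; the only guidance is that compound 1 and compound 2, which differ in the whole pattern of substituents on that ring, are within the scatter of each other, and that the single listed step is also small. A step of no more than the scatter is therefore expected, if anything towards a slightly higher number, as a 1.3-fold higher number from compound 1 to compound 4 (0.12 log units; within the scatter). Compound 4 is estimated at 700 nM, with a range from 350 nM to 1400 nM.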

Compound 4, concentration for 50% growth inhibition: 794 nM
The estimate for compound 4 lay 1.1-fold (0.05 log units) below the measured number; low and high end bracket the measured number.
By their numbers in this assay, from the lowest: compounds 1, 2, 4 and 3 (each within the scatter of the next).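

In this assay, hydrogen in place of trifluoromethyl on this aromatic carbon gives a 1.5-fold higher number from compound 1 to compound 4 (0.18 log units; within the scatter) and so stays inside the scatter: at this position, meta to a trifluoromethyl group, the second trifluoromethyl group of compound 1 is not shown to matter for the read-out. Among the compounds shown here, the comparison with the dichloro compound gives a 1.1-fold higher number from compound 2 to compound 4 (0.03 log units; within the scatter) for 3-(trifluoromethyl)phenyl in place of 3,4-dichlorophenyl on an amide-type nitrogen, so these two substituent patterns cannot be told apart on this read-out, and compound 4, with a single trifluoromethyl group on that ring, sits among the earlier compounds with no order among them. Nothing measured alongside these numbers speaks to what lies behind either step.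

All steps shown on this ring stay inside the scatter, so it remains open whether any change there can move the number beyond it, and whether the ring needs its last trifluoromethyl group at all. Equally open is how an amine or a carboxylic acid in place of hydrogen at this position would read, since only halogen and trifluoromethyl substituents appear on this ring among the compounds shown.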